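Phenoxy in Place of Hydroxy: Expected Stability of Compound 4

The source may report more compounds than this note shows. Statements on the series, on what has been measured and on what is new or still open speak of the compounds shown alone.

Compound 2 `COc1cc(OCc2cccc(O)c2)c2cc(-c3cn4nc(OC)sc4n3)oc2c1` stands highest of the three compounds measured in an ADME assay on microsomes from liver (Rattus norvegicus) for metabolic stability, with a stated time of 10 min; on this read-out lower numbers stand for a less stable compound and higher numbers for a more stable compound. In this assay compound 2 gives 49%. Compound 1 `COc1cc(OCc2ccccc2OC)c2cc(-c3cn4nc(OC)sc4n3)oc2c1` gives 28%, and compound 3 `Cc1nn2cc(-c3cc4ccccc4o3)nc2s1`, which carries a bare core without the benzyloxy arm and the methoxy groups, gives 4%. Compound 3 is therefore the weakest of the three, and compound 2 the most stable, with both gaps beyond the scatter.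

Compound 4 `COc1cc(OCc2cccc(Oc3ccccc3)c2)c2cc(-c3cn4nc(OC)sc4n3)oc2c1` differs from compound 2 by phenyl in place of hydrogen on an oxygen on an aromatic ring, so the free hydroxy of compound 2 becomes a phenoxy. Within the data shown here, of the measured steps only one bears on this change: a number 21 percentage points higher from compound 1 to compound 2 (beyond the scatter), where a methoxy-bearing ring gave way to a hydroxy-bearing ring and the remaining fraction rose. Among the measured compounds shown here, compound 4 moves the oxygen back from a free hydroxy to a substituted one, and the expectation is that the step of a number 24 percentage points lower from compound 2 to compound 4 (beyond the scatter) runs in the opposite direction, by a modest amount beyond the scatter, although no measured pair tests a phenoxy directly. Compound 4 is thus estimated to give 25% in this assay, within a range from 8% to 45%.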

Compound 4, percent of the compound remaining: 42%
Beside the measured number, compound 4's estimate is 17 percentage points below it, within the range that was stated.
By their numbers in this assay, from the lowest: compound 3; then compound 1; then compounds 4 and 2 (each within the scatter of the next).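

In this assay the change from hydroxy to phenoxy gives a number 7 percentage points lower from compound 2 to compound 4 (within the scatter), so this oxygen on an aromatic ring carries a phenyl in place of hydrogen without a shift that can be told from repeated measurements. The earlier step, a number 21 percentage points higher from compound 1 to compound 2 (beyond the scatter), exchanged 2-methoxyphenyl for 3-hydroxyphenyl and so altered both the group and where it sits; the new pair changes only what stands on the oxygen, and it shows that a free hydroxy at this place is not needed for a number of this size. Nothing shown here gives a reason why the added phenyl leaves the read-out within the scatter.

The compounds shown leave open how the number would run with a methyl, a longer alkyl chain or a chain ending in an amine on this same oxygen, since only hydrogen and phenyl appear there. They also leave open whether a carboxylic acid on the added phenyl would keep compound 4 within the scatter of compound 2.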